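This account rests on a few compounds, and the source may have more. Where it says the series, first, only, none or still open, it means among the compounds named here.

In a functional assay on HeLa cells (Homo sapiens) for inhibition, read by MTT assay, with a stated time of 48 h (on this read-out lower numbers stand for stronger inhibition and higher numbers for weaker inhibition), compound 1 `O=C(/C=C/c1ccccc1Br)c1ccc[nH]1` gives 44000 nM, and compound 2 `O=C(/C=C/c1ccccc1Cl)c1ccco1` gives 26000 nM. Compound 2 holds the lower of the two numbers, yet compound 1 stands nearest and its number lies within the scatter of it. Compound 3 `O=C(/C=C/c1cc([N+](=O)[O-])ccc1Cl)c1ccco1` has not been measured in this assay. It differs from compound 2 in one place: nitro in place of hydrogen on an aromatic carbon. For the measured compounds named here, no measured pair shows such a step, so its size is uncertain. A modest step downward, somewhat beyond the scatter, is expected, a 2.2-fold lower number from compound 2 to compound 3 (0.34 log units; beyond the scatter). Compound 3 is therefore estimated at 12000 nM, with a range from 3000 nM to 40000 nM.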

Compound 3, half-maximal inhibitory concentration: > 100000 nM
Compound 3: a limit, no number; the forecaster's own chance of this, stated with the estimate: 5%; middle value at least 8.3-fold (0.92 log units) away from the limit.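

On this aromatic carbon, para to the chloro group, nitro in place of hydrogen weakens inhibition in this assay, with an at least 3.8-fold higher number from compound 2 to compound 3 (0.58 log units; beyond the scatter). This is the first step that can be read among these compounds, and it shows that the position responds to substitution, here toward weaker inhibition. The value of compound 3 is a limit and not a number, and the step gives only its smallest possible size: the limit of > 100000 nM in this assay, at which 1 of the 3 values shown sits.

The compounds shown leave open whether an amine or a carboxylic acid in place of the same hydrogen would move the number the same way. They also leave open whether nitro would do so on the core of compound 1.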